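The compounds below may be only part of what the source reports. "The series", "measured", "known", "first", "only" and "open" are said of these compounds alone.

Among the measured compounds shown here, compound 1 `Cc1ccccc1Nc1nc(Nc2ccc(N3CCN(C)CC3)cn2)ncc1Cl` is one of three compounds measured in a functional assay on MDA-MB-231 cells (Homo sapiens) for inhibition, read by CCK-8 assay, with a stated time of 48 h; a higher number here means a weaker inhibitor of growth, a lower number a stronger inhibitor of growth. In this assay compound 1 gives 7470 nM. Its nearest neighbour is compound 3 `Cc1ccccc1Nc1nc(Nc2ccc(N3CCCN(C)CC3)cc2)ncc1Cl`, which in this assay gives 6390 nM; the two numbers lie within the scatter of each other, so nothing separates them. Compound 2 `CCN1CCN(c2ccc(Nc3ncc(Cl)c(Nc4ccccc4C)n3)nc2)CC1` stands apart: in this assay compound 2 gives > 100000 nM, which is a limit of the assay and not a number. For the measured compounds named here, the only measured step that differs in one place is an at least 13-fold higher number from compound 1 to compound 2 (1.12 log units; beyond the scatter), and it ends at the limit of > 100000 nM in this assay, at which 1 of the 3 values shown sits.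

Compound 4 `COc1ccc(Nc2nc(Nc3ccc(N4CCN(C)CC4)cn3)ncc2Cl)cc1` has not yet been measured. It differs from compound 1 by 4-methoxyphenyl in place of 2-methylphenyl on a nitrogen on an aromatic ring. Going by the values given here, no measured step touches that nitrogen or the group it carries, so the one step in hand gives no guidance on direction or size for this change. Compound 4 is therefore expected to stay within the scatter of compound 1, with the step estimated as a 1.0-fold higher number from compound 1 to compound 4 (0.00 log units; within the scatter) in this assay. The estimate for compound 4 in this assay is 7500 nM, with a range from 2000 nM to 30000 nM to reflect the absence of any comparable measured change.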

Compound 4, concentration for 50% growth inhibition: 8020 nM
The estimate for compound 4 lay 1.1-fold (0.03 log units) below the measured number; the range from low to high includes it.
By their numbers in this assay, from the lowest: compounds 3, 1 and 4 (each within the scatter of the next). At a limit, above all of these: compound 2.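

In this assay, among the compounds shown here, 4-methoxyphenyl in place of 2-methylphenyl on the nitrogen on an aromatic ring gives a 1.1-fold higher number from compound 1 to compound 4 (0.03 log units; within the scatter), so the first measured change at this position does not separate the two compounds. For the compounds shown here, the entering group has one hydrogen-bond acceptor where the leaving group has none, yet the only step beyond the scatter remains an at least 13-fold higher number from compound 1 to compound 2 (1.12 log units; beyond the scatter), which lies at the other end of the molecule and ends at a limit of the assay, not a number. Nothing measured here bears on why compound 4 and compound 1 are not separated.

The step from compound 1 to compound 4 exchanges the substituent and its printed ring position together, so the compounds shown cannot tell what 2-methoxyphenyl or 4-methylphenyl would give on the same nitrogen. From the compounds shown here alone, it also remains open whether a phenyl ring carrying an amine or a carboxylic acid, or a longer chain in place of the methoxy group, would stay within the scatter of compound 1.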